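The source may hold more compounds than are shown below. What is called first, only, known or untested is meant among the compounds shown, and "the series" means these compounds.

Compound 2 `CCCCCCCCCCCCOc1ccc(NC(=O)Oc2ccccc2F)cc1` gives, in an assay on H4 cells for inhibition of Fatty-acid amide hydrolase 1 (Homo sapiens) (a lower number here means a stronger inhibitor, a higher number a weaker inhibitor), 13 nM. This is the lowest of the three numbers on hand, though compound 1 `CCCCCCCCOc1ccc(NC(=O)Oc2ccccc2F)cc1`, which gives 19 nM, and compound 3 `CCCCOc1ccc(C(CC)NC(=O)Oc2ccc(F)cc2F)cc1`, which gives 21 nM, both sit within the scatter of it. Among the compounds with values here, the only single-point step measured so far, a 1.5-fold lower number from compound 1 to compound 2 (0.16 log units; within the scatter), concerns the chain on the ring oxygen and leaves the oxygen next to the carbonyl group untouched. Compound 4 `CCCCCCCCCCCCOc1ccc(NC(=O)ON=C(C)C)cc1` differs from compound 2 on that oxygen: a group of 4 heavy atoms (3 carbon, 1 nitrogen; no ring) in place of a group of 7 heavy atoms (6 carbon, 1 fluorine; one six-membered aromatic ring of carbon only), on an oxygen next to a carbonyl group. Within the data shown here, no measured step touches this change; compound 3 differs from compound 2 in several places at once, so its value gives no isolated read on it. With nothing to anchor the step, for compound 4 in this assay a higher number is expected, with a wide range: 150 nM, between 20 nM and 1500 nM. The expected step is a 12-fold higher number from compound 2 to compound 4 (1.06 log units; beyond the scatter), a provisional figure until a measurement is known.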

Compound 4, half-maximal inhibitory concentration: 5 nM
Compound 4: middle estimate off by 30-fold (1.48 log units), on the high side; the whole stated range lies above it.
By their numbers in this assay, from the lowest: compound 4; then compounds 2, 1 and 3 (each within the scatter of the next).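

On an oxygen next to a carbonyl group, the 2-fluorophenyl group is not needed to keep a low number in this assay: with the chain on the ring oxygen held constant, the group with no ring that replaces it gives a 2.6-fold lower number from compound 2 to compound 4 (0.41 log units; beyond the scatter). This pair is the only isolated read on this position, as the earlier step concerned the chain alone, and it shows that an aromatic ring can leave this oxygen without the number rising. Nothing on hand offers an explanation for the direction of this step.

Within the data shown here, only one pair reads this position, so it remains open whether the step holds with the shorter chain of compound 1. Also open, on these data alone, is how a plain phenyl or a cyclohexyl group would compare on this oxygen, which would separate the fluorine from the ring itself.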